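The source may report more compounds than this note shows. Statements on the series, on what has been measured and on what is new or still open speak of the compounds shown alone.

Compound 1, with the structure `CCCOC(=O)C1=C(C)NC(=S)NC1c1ccco1`, is measured in an assay on membranes from HEK293 cells for displacement of a labelled ligand from adenosine receptor A2b (Homo sapiens), read by scintillation counting, with a stated time of 30 min, tested at 1 uM (a higher number here means more inhibition at the concentration tested (going by the name of the read-out), a lower number less inhibition), where compound 1 gives 46%. Compound 2, with the structure `CC1=C(C(=O)OCC(C)C)C(c2ccco2)NC(=S)N1`, differs from compound 1 by methyl in place of hydrogen on a saturated chain carbon bound to two saturated chain carbons; in this assay compound 2 gives 18%. The change costs a number 28 percentage points lower from compound 1 to compound 2 (beyond the scatter).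

Compound 3, with the structure `CCSC(=O)C1=C(C)NC(=O)NC1c1ccsc1`, belongs to a second core, and the difference between the two cores is not broken down here. In this assay compound 3 gives 17%, the lowest of the three numbers, one that lies within the scatter of compound 2 and beyond the scatter below compound 1.

Compound 4, with the structure `CC1=C(C(=O)SC(C)C)C(c2ccsc2)NC(=O)N1`, has not yet been measured. It differs from compound 3 by methyl in place of hydrogen on a saturated chain carbon bound to a saturated chain carbon and a sulfur. Among the compounds with values here, this is the same kind of change as the one from compound 1 to compound 2, though not the same: in the first pair the added methyl sits on a saturated chain carbon bound to two saturated chain carbons, while in the second pair it sits on a saturated chain carbon bound to a saturated chain carbon and a sulfur.

Within the data shown here, the expectation for compound 4 in this assay rests on the one measured instance of this kind of change, the step of a number 28 percentage points lower from compound 1 to compound 2 (beyond the scatter), and on the fact that compound 3 already gives 17%, leaving little room for an equally large fall. Compound 4 is therefore expected to show a step of a number 9 percentage points lower from compound 3 to compound 4 (within the scatter) from compound 3. The estimate for compound 4 is 8%, with a plausible range from 0% to 25%.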

Compound 4, a percentage reported as inhibition, at one concentration (the size of the read-out at that concentration, not a potency): 14%
For compound 4 the middle estimate is 6 percentage points below the measured one; the range from low to high includes it.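

In this assay, within the data shown here, the change from ethylsulfanyl to isopropylsulfanyl gives a number 3 percentage points lower from compound 3 to compound 4 (within the scatter), so on this core the added methyl leaves no step that can be told from the usual spread of repeated measurements. The step seen on the core of compound 1 therefore does not carry over in size to the core of compound 3, and the two pairs disagree by more than the scatter allows: the same change on two cores in this assay, a number 28 percentage points lower (beyond the scatter) from compound 1 to compound 2 and a number 3 percentage points lower (within the scatter) from compound 3 to compound 4, 25 percentage points apart, beyond the scatter of two such steps This does not show which feature sets the two steps apart, as the two cores differ in more than one place, the added methyl has different neighbours in the two pairs, and two pairs read at a single concentration give no potency and no general rule for the series.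

The compounds shown leave open how either core would respond to a longer chain, such as butyl, or to a cyclopropyl group in the same place. They also leave open what the same methyl would do on a core that carries only one of the differences between the two cores, which is the comparison that could begin to separate them.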